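This account rests on a few compounds, and the source may have more. Where it says the series, first, only, none or still open, it means among the compounds named here.

For the measured compounds named here, compound 2 `Nc1nc(N)c2cc(CSC(=S)N3CCN(c4ccc([N+](=O)[O-])cc4)CC3)ccc2n1` gives 1470 nM in a functional assay on MCF7 cells (Homo sapiens) for antiproliferative activity, read by MTT assay, with a stated time of 72 h (a higher number here means a weaker inhibitor, a lower number a stronger inhibitor), the lower of the two numbers measured so far. Going by the values given here, its nearest neighbour, compound 1 `Nc1nc(N)c2cc(CSC(=S)N3CCN(c4ccc(F)cc4F)CC3)ccc2n1`, gives 3670 nM, and the only measured step is a 2.5-fold lower number from compound 1 to compound 2 (0.40 log units; beyond the scatter). Compound 3 `Nc1nc(N)c2cc(CSC(=S)N3CCN(c4ccccn4)CC3)ccc2n1` differs from compound 2 in one place: pyridin-2-yl in place of 4-nitrophenyl on an amine nitrogen in a ring. That single earlier step, one aromatic group exchanged for another on the same ring nitrogen, was modest and did not involve pyridin-2-yl, so guidance is thin. A modest rise in the number is expected, a 1.7-fold higher number from compound 2 to compound 3 (0.23 log units; within the scatter). For compound 3 the estimate is 2500 nM, within 900 nM to 7000 nM.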

Compound 3, half-maximal inhibitory concentration: 5110 nM
Beside the measured number, compound 3's estimate is 2.0-fold (0.31 log units) below it; the measured number falls inside the stated range.
By their numbers in this assay, from the lowest: compound 2; then compounds 1 and 3 (each within the scatter of the next).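

Exchanging the aromatic group on this ring nitrogen can shift the number beyond the scatter even when the new group is pyridin-2-yl (a 3.5-fold higher number from compound 2 to compound 3 (0.54 log units; beyond the scatter)), so 4-nitrophenyl holds the lowest number of the three in this assay. Pyridin-2-yl and 2,4-difluorophenyl cannot be separated (a 1.4-fold higher number from compound 1 to compound 3 (0.14 log units; within the scatter)), so only 4-nitrophenyl stands apart here. No measurement at hand accounts for these differences. Still open, going by these compounds, is whether the nitro group or the carbon-only ring goes with the lower number; plain phenyl or 4-aminophenyl at this nitrogen could separate the two.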